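The source may hold more compounds than are shown below. What is called first, only, known or untested is meant among the compounds shown, and "the series" means these compounds.

Compound 1 `C=CCn1c(=O)/c(=C\c2cccc(C)c2)[nH]c(=O)/c1=C\c1ccccc1OC`: 16000 nM
Compound 2 `C=CCn1c(=O)/c(=C\c2ccc(F)c(Br)c2)[nH]c(=O)/c1=C\c1ccccc1OC`: "not active" (no number reported)

Of the compounds shown here, two sharing one core have been tested in a functional assay on MOLT-4 cells (Homo sapiens) for cytotoxicity, read by CCK-8 assay, with a stated time of 72 h; a lower number here means a stronger inhibitor, a higher number a weaker inhibitor. Compound 1 gives 16000 nM, a weak result. Compound 2 carries a 3-bromo-4-fluorophenyl group in place of the 3-methylphenyl group of compound 1. In this assay compound 2 was reported as "not active" (no number reported), so no single number stands and its place on the scale is not fixed; it can only be said that no inhibition worth a number was seen.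

Compound 3 `C=CCn1c(=O)/c(=C\c2cccc(Br)c2)[nH]c(=O)/c1=C\c1ccccc1OC` is the next compound and has not yet been measured. Its difference from compound 2 is hydrogen in place of fluoro on an aromatic carbon. For the measured compounds named here, no measured pair shows what this change does on this core, so the size of the step in this assay cannot be drawn from the numbers at hand; the expectation is a small step, in no firm direction, not beyond the scatter. Both measured compounds are weak or without a number, and compound 3 is expected to stay in that weak region, near 20000 nM, between 5000 nM and 80000 nM.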

Compound 3, half-maximal inhibitory concentration: 5000 nM
Compound 3: middle estimate off by 4.0-fold (0.60 log units), on the high side, within the range that was stated.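

With hydrogen in place of the fluoro group, on the aromatic carbon ortho to a bromo group, compound 3 gives 5000 nM in this assay, whereas compound 2 was reported as not active; the change therefore separates a compound with a measured value from one without, although the size of the step cannot be read. Bromo in place of methyl on an aromatic carbon provides the first readable step on this core, a 3.2-fold lower number from compound 1 to compound 3 (0.51 log units; beyond the scatter), showing that this single replacement can move the result beyond the usual scatter, even though compound 3 remains a fairly weak inhibitor. Nothing in the material at hand explains either difference.

Two single changes on one shared core cannot show whether the same effects would hold with other neighbouring groups, so the fluoro result may be specific to the 3-bromophenyl setting. From the compounds shown here alone, it also remains open how an amine or a carboxylic acid would compare with bromo on that aromatic carbon, and whether any such group could bring the value much lower.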